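The source may hold more compounds than are shown below. What is called first, only, known or untested is meant among the compounds shown, and "the series" means these compounds.

Compound 2 `O=C(O)c1ccccc1-c1ccc(CCc2ncc(CCc3ccccc3)[nH]2)cc1` gives 174 nM in an in vitro functional assay on cells for agonist activity at Bombesin receptor subtype-3 (Mus musculus), read by luminescence and calcium flux (on this read-out higher numbers stand for an effect only at larger amounts of compound and lower numbers for an effect already at smaller amounts), the highest of the two numbers in hand. Compound 1 `O=C(O)c1ccccc1-c1ccc(CCc2ncc(Cc3cccc(F)c3)[nH]2)cc1` gives 7.9 nM there, and the step of a 22-fold higher number from compound 1 to compound 2 (1.34 log units; beyond the scatter) is the only measured one. Compound 3 `O=C(O)c1ccccc1-c1ccc(CCc2ncc(-c3ccccc3)[nH]2)cc1` differs from compound 2 by phenyl in place of phenethyl on an aromatic carbon. The measured step touches the same ring carbon but alters a different part of the group, so it bears only loosely on this change. A downward step is expected, since compound 1, with a shorter linker, gives 7.9 nM. The step of a 2.2-fold lower number from compound 2 to compound 3 (0.34 log units; beyond the scatter) is the estimate, with compound 3 expected at 80 nM, between 15 nM and 500 nM.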

Compound 3, half-maximal effective concentration: 872 nM
Beside the measured number, compound 3's estimate is 11-fold (1.04 log units) below it; the whole stated range lies below it.
By their numbers in this assay, from the lowest: compound 1; then compound 2; then compound 3.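

In this assay, among the compounds shown here, phenyl on this aromatic carbon gives the highest number so far, with a 5.0-fold higher number from compound 2 to compound 3 (0.70 log units; beyond the scatter) and a 110-fold higher number from compound 1 to compound 3 (2.04 log units; beyond the scatter). Removing the chain altogether therefore does not bring the number down, and the three compounds show no single trend with chain length, since the 3-fluorobenzyl of compound 1 stays lowest while phenethyl and phenyl both lie higher. No measurement at hand accounts for these shifts. The compounds shown leave open how an unsubstituted benzyl would compare at this carbon, which would separate the chain from the fluorine. They also leave open what a 3-fluorophenyl would give here.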